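A few compounds are considered here, and "the series" means these few. Any claim that something is new, unique, unknown or untested is made for them only; others in the source may bear on it.

Working notes on the series. Compound 1 `CC1=CCC[C@H]2[C@](C)(CC3=CC(=O)C=CC3=O)[C@@H](C)CC[C@]12C` and compound 2 `CC1=CCC[C@H]2[C@](C)(CC3=CC(=O)C(SC(C)C)=CC3=O)[C@@H](C)CC[C@]12C` share one core. In a functional assay on K562 cells (Homo sapiens) for cytotoxicity, read by MTT assay (a lower number here means a stronger inhibitor, a higher number a weaker inhibitor), compound 1 gives 4900 nM, while compound 2 gives 47500 nM, the higher of the two numbers and so the weaker result. Compound 3 `CC1=CCC[C@H]2[C@](C)(CC3=CC(=O)C(Sc4ccccc4)=CC3=O)[C@@H](C)CC[C@]12C` is next, and its change is phenyl in place of isopropyl on a sulfur. For the measured compounds named here, only one measured step bears on this, a 9.7-fold higher number from compound 1 to compound 2 (0.99 log units; beyond the scatter), where isopropylsulfanyl replaces hydrogen on a double-bonded ring carbon. Going by the values given here, no measured step varies the group on the sulfur, so the data fix neither the size nor the direction of this change, and the range stays wide. With compound 2 at 47500 nM, the higher end of the series, a small move downward in this assay is expected. The estimated step is a 2.2-fold lower number from compound 2 to compound 3 (0.33 log units; beyond the scatter). For compound 3 the expected value is 22000 nM, with an estimated range of 7000 nM to 70000 nM.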

Compound 3, half-maximal inhibitory concentration: 15200 nM
Estimate against measurement, compound 3: 1.4-fold (0.16 log units) above; measured number inside the range.
By their numbers in this assay, from the lowest: compound 1; then compound 3; then compound 2.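

In this assay the group on the sulfur makes a difference beyond the scatter: there is a 3.1-fold lower number from compound 2 to compound 3 (0.49 log units; beyond the scatter), so phenyl in place of isopropyl recovers part of the loss seen with isopropylsulfanyl. Phenylsulfanyl still does not match hydrogen on the double-bonded ring carbon, with a 3.1-fold higher number from compound 1 to compound 3 (0.49 log units; beyond the scatter), so both sulfur-linked groups shown give weaker results than compound 1. No evidence at hand bears on the reason for these differences.

From the compounds shown here alone, it remains open whether a group on the sulfur carrying an amine, a carboxylic acid or a longer chain would bring the number closer to that of compound 1 or pass it. Also open, going by these compounds, is how an amine attached directly to the same ring carbon, with no sulfur, would compare with hydrogen there.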